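Swapping chloro for amino on a dihydropyridine aryl ring

The compounds below may be only part of what the source reports. "The series", "measured", "known", "first", "only" and "open" are said of these compounds alone.

Measured compounds:
- Compound 1, `COC(=O)C1=C(C)N=C(C)/C(=C(/O)OC)C1c1c(F)cccc1Cl`: 7.59 nM
- Compound 2, `COC(=O)C1=C(C)N=C(C)/C(=C(\O)OC)C1c1cccc(OC(C)=O)c1`: 6030 nM
- Compound 3, `COC(=O)C1=C(C)N=C(C)/C(=C(\O)OC)C1c1ccccc1Cl`: 2.19 nM

All three compounds were tested in a functional assay (muscle tissue) with Cavia porcellus as the target; a higher number here means that more compound is needed for the effect, a lower number that less compound is needed. Among them compound 3, with 2.19 nM, shows the lowest number of the three. Its nearest neighbour is compound 1, whose value in this assay stands beyond the scatter above it, and compound 2 lies far higher still, a gap of many orders that is also well beyond the scatter.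

Compound 4, `COC(=O)C1=C(C)N=C(C)/C(=C(\O)OC)C1c1ccccc1N`, has not yet been measured. It differs from compound 3 in a single place: amino in place of chloro on an aromatic carbon. Going by the values given here, no measured pair in this set isolates this particular change, so its effect can only be anticipated. The group that enters brings one hydrogen-bond donor and one acceptor where chloro had none, and the only other departure from the substituted-chlorophenyl pattern in the set, compound 2, carries a far higher number. A loss of potency beyond the scatter is therefore expected, of roughly a 23-fold higher number from compound 3 to compound 4 (1.36 log units; beyond the scatter). Compound 4 is estimated at 50 nM, within a range from 8 nM to 400 nM.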

Compound 4, half-maximal effective concentration: 39800 nM
Estimate against measurement, compound 4: 800-fold (2.90 log units) below; the measured number lies above the stated range.
By their numbers in this assay, from the lowest: compound 3; then compound 1; then compound 2; then compound 4.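

In this assay, going by these compounds alone, the change from 2-chlorophenyl to 2-aminophenyl is the first comparison in the set that isolates a single place, and it gives a large step, an 18000-fold higher number from compound 3 to compound 4 (4.26 log units; beyond the scatter). It shows that this aromatic carbon, ortho to a large group, does not treat all single heavy atoms alike, since amino and chloro each bring one heavy atom yet the numbers lie far apart. Nothing measured on these compounds accounts for the size of this step.

The compounds shown leave open whether the loss belongs to amino specifically or would follow other replacements of chloro at this carbon, such as methyl, methoxy or hydroxyl. A dimethylamino or acetamido group there would show whether the amino hydrogens matter.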